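Swapping the Amino Group on a Carbonyl Carbon

This account rests on a few compounds, and the source may have more. Where it says the series, first, only, none or still open, it means among the compounds named here.

- compound 1 `CCCCNc1nc(N)nc2ccccc12`: 2700 nM
- compound 2 `CCCCNc1nc(N)nc2cccc(C(=O)N(C)Cc3ccccc3)c12`: 575 nM

The measure here is an ADME assay on the whole organism (Portal vein, Rattus norvegicus, strain Sprague-Dawley) for pharmacokinetics, at a dose of 10 mg/kg by the oral route; a higher number here means more compound in the circulation at the dose given, a lower number less compound in the circulation. On it, compound 2 gives 575 nM, the lower of the two numbers, while compound 1 gives 2700 nM, and that gap lies beyond the usual scatter.

Compound 3 `CCCCNc1nc(N)nc2cccc(C(=O)N[C@@H](C)c3ccccc3)c12` has not yet been measured. It differs from compound 2 in one place: (1-phenylethyl)amino in place of benzyl(methyl)amino on a carbonyl carbon. In words, (1-phenylethyl)amino stands in place of benzyl(methyl)amino on a carbonyl carbon.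

Among the compounds with values here, no measured pair shows this kind of swap, so the expectation stays close to compound 2 at 575 nM, with no step beyond the scatter in this assay and wide uncertainty. The expected step is a 1.0-fold higher number from compound 2 to compound 3 (0.02 log units; within the scatter). The estimated value for compound 3 is 600 nM, within an expected range from 170 nM to 2000 nM.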

Compound 3, maximal plasma concentration: 759 nM
Estimate against measurement, compound 3: 1.3-fold (0.10 log units) below; low and high end bracket the measured number.
By their numbers in this assay, from the lowest: compounds 2 and 3 (each within the scatter of the next); then compound 1.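

On a carbonyl carbon, (1-phenylethyl)amino and benzyl(methyl)amino hold the same atoms joined differently, yet the first carries a hydrogen-bond donor, the amide hydrogen, and a defined stereocentre, which the second lacks. In this assay, this swap gives a 1.3-fold higher number from compound 2 to compound 3 (0.12 log units; within the scatter), so this one rearrangement leaves the two compounds indistinguishable on this read-out. Nothing available bears on why the two numbers sit so close.

Still open, as far as these compounds go, is whether the mirror-image form of compound 3 would give a similar number. From the compounds shown here alone, it is also open whether an amine without the aromatic ring, such as morpholine or dimethylamine, or a chain ending in a carboxylic acid, would stay level with these two compounds on the same carbonyl carbon.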